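Chloro in Place of Methoxy on a Shared Core

A few compounds are considered here, and "the series" means these few. Any claim that something is new, unique, unknown or untested is made for them only; others in the source may bear on it.

Of the compounds shown here, three built on one shared core have been tested in an ADME assay on HepG2 cells (Homo sapiens) for cytotoxicity, with a stated time of 48 h; on this read-out higher numbers stand for weaker inhibition and lower numbers for stronger inhibition. Compound 1 `Cn1c(SCc2ccc(Cl)cc2)nnc1-c1cc([N+](=O)[O-])cc([N+](=O)[O-])c1` gives a value that is a limit of the assay, > 30000 nM. Compound 2 `CCCSc1nnc(-c2cc([N+](=O)[O-])cc([N+](=O)[O-])c2)n1Cc1ccccc1` likewise reaches only the limit, > 30000 nM. Compound 3 `COc1ccc(CSc2nnc(-c3cc([N+](=O)[O-])cc([N+](=O)[O-])c3)n2Cc2ccccc2)cc1` also sits at the limit, > 30000 nM. Among the compounds with values here, because every measured value sits at the same limit (the limit of > 30000 nM in this assay, at which 3 of the 3 values shown sit), no compound can be told apart from another on these numbers, and the only step between two compounds that differ in one place, a step that the two limits leave unreadable from compound 2 to compound 3, cannot be read.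

Compound 4 `O=[N+]([O-])c1cc(-c2nnc(SCc3ccc(Cl)cc3)n2Cc2ccccc2)cc([N+](=O)[O-])c1` has not yet been measured. It differs from compound 3 in one place: chloro in place of methoxy on an aromatic carbon. Within the data shown here, no measured step bears directly on this exchange, and the one step that is known came out unreadable, so there is no ground to expect a shift beyond the scatter in either direction. The expectation is that compound 4 also sits at the limit, with an estimated value of 45000 nM, somewhere between 20000 nM and 120000 nM. The step that this estimate implies, a step that the limit leaves unreadable from compound 3 to compound 4, is expected to be nothing beyond the scatter.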

Compound 4, half-maximal inhibitory concentration: > 30000 nM
Compound 4: a limit, no number; the forecaster's own chance of this, stated with the estimate: 85%; the middle value lies beyond the limit too.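

In this assay compound 4 gives > 30000 nM, which is a limit and not a number. The steps joining compound 1, compound 2 and compound 3 to compound 4 therefore cannot be read: the limit of > 30000 nM in this assay, at which 4 of the 4 values shown sit.

The compounds shown leave open whether any of them truly differs from another in this assay, and how far beyond the limit each one lies.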